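Sulfonyl quinoxaline series: a methoxy on the sulfonyl phenyl

This account rests on a few compounds, and the source may have more. Where it says the series, first, only, none or still open, it means among the compounds named here.

Measured so far:
compound 1 `COc1cc(Nc2nc3ccccc3nc2S(=O)(=O)c2ccccc2)cc(OC)c1` gives 950 nM in a functional assay on HCT-116 cells (Homo sapiens) for cytotoxicity, read by MTT assay, with a stated time of 72 h; on this read-out lower numbers stand for stronger inhibition and higher numbers for weaker inhibition
compound 2 `Nc1cccc(Nc2nc3ccccc3nc2S(=O)(=O)c2ccccc2)c1` gives 1540 nM in this assay
compound 3 `O=S(=O)(c1ccccc1)c1nc2ccccc2nc1Nc1ccc(Cl)cc1` gives 2000 nM in this assay

Compound 1 has the lowest of the three numbers. Its nearest neighbour is compound 2, with a 1.6-fold higher number from compound 1 to compound 2 (0.21 log units; within the scatter), a step within the scatter; the furthest is compound 3, with a 2.1-fold higher number from compound 1 to compound 3 (0.32 log units; beyond the scatter), a modest step beyond it. Between compound 2 and compound 3 the step is a 1.3-fold higher number from compound 2 to compound 3 (0.11 log units; within the scatter), again within the scatter. All three measured steps change only the aryl on the nitrogen attached to the shared core.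

Compound 4 `COc1ccc(S(=O)(=O)c2nc3ccccc3nc2Nc2cc(OC)cc(OC)c2)cc1` is the next entry. Its difference from compound 1 is methoxy in place of hydrogen on an aromatic carbon, on the phenyl carried by the sulfonyl group, para to a large group. Among the measured compounds shown here, no measured step touches that phenyl, so none of the three bears directly on this change. With nothing to point either way, the expectation is a step of no more than the scatter, a 1.1-fold lower number from compound 1 to compound 4 (0.02 log units; within the scatter), in this assay. Compound 4 is therefore expected at 900 nM, within 450 nM to 1900 nM.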

Compound 4, half-maximal inhibitory concentration: 13400 nM
Compound 4: the middle estimate sits 15-fold (1.17 log units) below what was measured, outside the stated range (above it).
By their numbers in this assay, from the lowest: compounds 1, 2 and 3 (each within the scatter of the next, the first and the last beyond it); then compound 4.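

Methoxy in place of hydrogen on the phenyl carried by the sulfonyl group, para to a large group, brings a 14-fold higher number from compound 1 to compound 4 (1.15 log units; beyond the scatter) in this assay, so this ring is a position where a single substituent counts. The earlier steps shown here changed only the aryl on the nitrogen and stayed within the scatter or modestly beyond it, whereas this one change on the other aryl is large. Nothing at hand accounts for this step.

Open, on these data alone, is whether a hydroxyl, a fluorine or a methyl in that place would bring a step of similar size, or whether methoxy stands apart. Also open, as far as these compounds go, is whether 4-methoxyphenyl on the sulfonyl group would bring the same step with the 3-aminophenyl of compound 2 or the 4-chlorophenyl of compound 3 on the nitrogen.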